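This account rests on a few compounds, and the source may have more. Where it says the series, first, only, none or still open, it means among the compounds named here.

Measured compounds:
Compound 1 `COC(=O)c1ccc(NCc2cncn2Cc2ccccc2)cc1-c1ccccc1`: > 1000 nM
Compound 2 `c1ccc(-c2ccc(Cn3cncc3CNc3ccc(-c4ccccc4)c(-c4ccccc4)c3)cc2)cc1`: > 10000 nM

Compound 1 was tested in a toxicity assay on NIH3T3 cells (Mus musculus) for cytotoxicity, read by resazurin assay (a higher number here means that more compound is needed for the effect, a lower number that less compound is needed), and gives > 1000 nM, which is a limit of the assay rather than a measured number; the true value of compound 1 sits (the limit of > 1000 nM in this assay, at which 1 of the 2 values shown sits). Compound 2 gives > 10000 nM in this assay, also a limit. Among the compounds with values here, the two compounds differ in many places at once, so the pair says only that both stop at a limit, with no single step to weigh.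

Compound 3 `COC(=O)c1ccc(NCc2cncn2Cc2cccc(C)c2)cc1-c1ccccc1` is the next compound, and it differs from compound 1 in one place: methyl in place of hydrogen on an aromatic carbon. Within the data shown here, no measured pair here shows the effect of this change, so no direction can be read from the data. A step no larger than the usual scatter is expected from compound 1 to compound 3, namely a step that the limit leaves unreadable from compound 1 to compound 3. Compound 3 is therefore estimated at 3000 nM in this assay, within a range from 1000 nM to 10000 nM, most likely again reported only as a limit.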

Compound 3, half-maximal effective concentration: > 10000 nM
Compound 3 was reported as a limit (the forecaster's own chance of this, stated with the estimate: 75%); middle value at least 3.3-fold (0.52 log units) from the limit.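

Compound 1 and compound 3 both stop at a limit in this assay, and the step between them, methyl in place of hydrogen, cannot be read. The compounds shown leave open how much of each is actually needed for the effect, and whether the methyl changes that amount.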